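Lengthening the chain toward the imidazole ring

The source may report more compounds than this note shows. Statements on the series, on what has been measured and on what is new or still open speak of the compounds shown alone.

Compound 1 `CCN/C(=N\C#N)NCCCCc1c[nH]cn1` and compound 2 `CC(C)CN/C(=N\C#N)NCCCCc1c[nH]cn1` were tested in an in vitro functional assay on Sf9 cells for antagonist activity at histamine H2 receptor (Homo sapiens); a lower number here means a less potent compound, a higher number a more potent compound, by a factor of ten per unit of this negative logarithm. In this assay compound 1 reaches only a limit of < 5. In this assay compound 2 likewise reaches only a limit of < 5. The step that the two limits leave unreadable from compound 1 to compound 2 therefore cannot be read, since (the limit of < 5 in this assay, at which 2 of the 2 values shown sit). Compound 3 `CC(C)CN/C(=N\C#N)NCCCCCc1c[nH]cn1` differs from compound 2 by (1H-imidazol-4-yl)methyl in place of 1H-imidazol-4-yl on a saturated chain carbon, four bonds along the chain from an amine nitrogen. Within the data shown here, no measured step covers this change, and both measured values are limits, so little is known beyond where compound 2 stands. Compound 3 is expected to give about 5, between 4 and 6. The expected step is a number no lower from compound 2 to compound 3 (the limit leaves the size open), that is, no clear gain beyond the scatter.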

Compound 3, negative logarithm of the antagonist equilibrium constant: < 5
Compound 3: no number, only a limit; the forecaster's own chance of this, stated with the estimate: 50%; the middle value lies on the limit itself.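

No step can be read from compound 2 to compound 3, since each gives only a limit and not a number: the limit of < 5 in this assay, at which 3 of the 3 values shown sit.

The compounds shown leave open how potent each one really is, and whether (1H-imidazol-4-yl)methyl in place of 1H-imidazol-4-yl changes potency at all.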